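Adding a third methoxy to the aryl ketone of a chalcone-pyrazole

The source may report more compounds than this note shows. Statements on the series, on what has been measured and on what is new or still open speak of the compounds shown alone.

Measured compounds:
Compound 1 `COc1cc(-c2cc(/C=C/C(=O)c3ccc(N)cc3)[nH]n2)cc(OC)c1OC` gives 91% in a functional assay on UACC-257 cells (Homo sapiens) for cytotoxicity, read by sulforhodamine B assay, with a stated time of 48 h, tested at 1 uM; on this read-out lower numbers stand for a stronger effect and higher numbers for a weaker effect at the one concentration tested.
Compound 2 `COc1ccc(-c2cc(/C=C/C(=O)c3cc(OC)c(OC)c(OC)c3)[nH]n2)cc1OC` gives 89% in this assay.
Compound 3 `COc1ccc(C(=O)/C=C/c2cc(-c3cc(OC)c(OC)c(OC)c3)n[nH]2)cc1OC` gives 81% in this assay.

Compound 3 holds the lowest of the three numbers, but neither neighbour is separated from it by more than the scatter: compound 2 sits a little higher, and the step of a number 10 percentage points lower from compound 1 to compound 3 (within the scatter) is likewise within the scatter. So on the numbers shown, the three compounds are indistinguishable.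

Compound 4 `COc1cc(C(=O)/C=C/c2cc(-c3cc(OC)c(OC)c(OC)c3)n[nH]2)cc(OC)c1OC` is the next step from compound 3: methoxy in place of hydrogen on an aromatic carbon. Among the compounds with values here, the only measured step that touches the same part of the molecule, the group on the carbonyl carbon, is a number 10 percentage points lower from compound 1 to compound 3 (within the scatter), and it did not leave the scatter even though it swapped an entire aryl substituent. Compound 2, which already carries a trimethoxyphenyl on its carbonyl, gives a number close to that of compound 3. The expectation for compound 4 is therefore no step beyond the scatter, a number 4 percentage points higher from compound 3 to compound 4 (within the scatter). Compound 4 is estimated at 85%, with a range from 70% to 98%.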

Compound 4, a percentage reported as activity, at one concentration (the size of the read-out at that concentration, not a potency): 85%
Compound 4: the middle estimate sits on the measured number at the digits printed, within the range that was stated.
By their numbers in this assay, from the lowest: compounds 3, 4, 2 and 1 (each within the scatter of the next).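

In this assay, a methoxy in place of hydrogen on an aromatic carbon, ortho to a methoxy group, was now tested on both aryl groups of the series, and neither step leaves the scatter: a number 4 percentage points higher from compound 3 to compound 4 (within the scatter) on the ring at the carbonyl, and a number 4 percentage points lower from compound 2 to compound 4 (within the scatter) on the other ring. Within the data shown here, earlier comparisons had only exchanged a whole aryl group, so this is the first sign that this single position tolerates a methoxy or a hydrogen with no readable change in the number at the one concentration tested. No measurement is available that would explain this result.

From the compounds shown here alone, whether an amine, a carboxylic acid or a longer chain such as ethoxy at this position would move the number beyond the scatter remains open. So does the question of whether any of these compounds would separate from the others at a different concentration.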